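Methoxy to Ethyl Where Every Value Is a Limit

The source may report more compounds than this note shows. Statements on the series, on what has been measured and on what is new or still open speak of the compounds shown alone.

Compound 1 is `COCCOc1nc(N)nc2c1ncn2/C=C1/CC1(CO)CO`. In an ADME assay on Akata cells (Homo sapiens) for cytotoxicity, with a stated time of 7 days (on this read-out higher numbers stand for lower toxicity in this test and lower numbers for higher toxicity in this test), compound 1 gives > 20000 nM, which is a limit of the test and not a number.
Compound 2 is `Nc1nc(NC2CC2)c2ncn(/C=C3/CC3(CO)CO)c2n1`. In this assay compound 2 gives > 20000 nM, again only a limit.
Compound 3 is `CCCCCCSc1nc(N)nc2c1ncn2/C=C1/CC1(CO)CO`. In this assay compound 3 gives > 20000 nM, also a limit.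

Compound 1 therefore stands only at a limit, as do the two other compounds measured. The steps from compound 1 to compound 2 a step that the two limits leave unreadable from compound 1 to compound 2, from compound 1 to compound 3 a step that the two limits leave unreadable from compound 1 to compound 3 and from compound 2 to compound 3 a step that the two limits leave unreadable from compound 2 to compound 3 cannot be sized, because of the limit of > 20000 nM in this assay, at which 3 of the 3 values shown sit.

Compound 4 is `CCCCOc1nc(N)nc2c1ncn2/C=C1/CC1(CO)CO`, and it differs from compound 1 in one place: ethyl in place of methoxy on a saturated chain carbon, two bonds along the chain from an oxygen on an aromatic ring. Among the measured compounds shown here, no measured step bears on this change, and the three measured steps bear on nothing, since each is hidden by the limit. The expectation is that compound 4 will likewise sit at the limit, so the step from compound 1 to compound 4 is estimated as a step that the limit leaves unreadable from compound 1 to compound 4. Compound 4 is expected to show 30000 nM, between 15000 nM and 80000 nM.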

Compound 4, half-maximal cytotoxic concentration: > 20000 nM
Compound 4: only a limit was reported; the forecaster's own chance of this, stated with the estimate: 85%; the middle value is on the limit's open side.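

No new step can be read between compound 4 and compound 1, compound 2 or compound 3, since all four stand only at a limit: (the limit of > 20000 nM in this assay, at which 4 of the 4 values shown sit). The compounds shown leave open how their side groups compare in this assay and at what concentration any of them turns toxic.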